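A few compounds are considered here, and "the series" means these few. Any claim that something is new, unique, unknown or untested is made for them only; others in the source may bear on it.

Four compounds share one core, shown in the structure of compound 1 `CN1CCN(c2ccc(/C=C3/SC(Nc4ccccc4)=NC3=O)cc2)CC1`. Compound 3 `CCN(CC)c1ccc(/C=C2/SC(N(C)c3ccccc3)=NC2=O)cc1` carries a methyl and a phenyl on the amine nitrogen of that core and a diethylamino group on the aromatic ring. In an ADME assay on cells (Homo sapiens) for cytotoxicity, read by sulforhodamine B assay, with a stated time of 48 h (on this read-out higher numbers stand for an effect only at larger amounts of compound and lower numbers for an effect already at smaller amounts), compound 3 gives only a limit, > 100000 nM. Compound 1, with a hydrogen instead of the methyl and a 4-methylpiperazin-1-yl group on the ring, gives 6400 nM in this assay. Compound 2 `CN1CCN(c2ccc(/C=C3/SC(N(c4ccccc4)c4ccccc4)=NC3=O)cc2)CC1` carries a second phenyl on the amine nitrogen. In this assay compound 2 gives only a limit, > 100000 nM. For the measured compounds named here, the single measured step, an at least 15-fold higher number from compound 1 to compound 2 (1.19 log units; beyond the scatter), therefore ends at the limit of > 100000 nM in this assay, at which 2 of the 3 values shown sit.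

Compound 4 `CN1CCN(c2ccc(/C=C3/SC(N(C)c4ccccc4)=NC3=O)cc2)CC1` differs from compound 3 in one place: 4-methylpiperazin-1-yl in place of diethylamino on an aromatic carbon. Going by the values given here, no measured step concerns this position; the one step known concerns the amine nitrogen, not the ring substituent. Compound 3 starts at a limit, and the closest measured neighbour with the same ring group, compound 1, differs also at the nitrogen, so no direction can be drawn. The expected step is a number no higher from compound 3 to compound 4 (the limit leaves the size open), meaning no change beyond the scatter is estimated. Compound 4 is expected to give about 100000 nM, within 20000 nM to 300000 nM, most probably again reported only as a limit.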

Compound 4, half-maximal effective concentration: > 100000 nM
Compound 4 was reported as a limit (the forecaster's own chance of this, stated with the estimate: 65%); the middle value sits exactly at the limit.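

Compound 4 shows that a phenyl on the amine nitrogen is not needed for the change seen with compound 2: with the 4-methylpiperazin-1-yl group kept on the ring, a methyl in place of the hydrogen already gives an at least 15-fold higher number from compound 1 to compound 4 (1.19 log units; beyond the scatter) in this assay. Among the pairs that differ in one place, compound 1 therefore keeps a measurable effect on the cells with its hydrogen on that nitrogen, while compound 2 and compound 4, with a second group there, reach only a limit at the top of the tested range. The swap of diethylamino for 4-methylpiperazin-1-yl and the swap of phenyl for methyl cannot be read, because both ends of each step sit at the same limit: the limit of > 100000 nM in this assay, at which 3 of the 4 values shown sit.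

Any difference among compound 2, compound 3 and compound 4 stays hidden, so the ring group's influence is unknown when the nitrogen carries a second group. The compounds shown also leave open how an ethyl on the amine nitrogen, or a morpholin-4-yl group on the aromatic ring of compound 1, would read in this assay.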